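The compounds below may be only part of what the source reports. "The series", "measured", "known", "first", "only" and "open" are said of these compounds alone.

Series notes, growth inhibition of a breast cancer line.

Of the compounds shown here, two have numbers so far in a functional assay on MDA-MB-468 cells (Homo sapiens) for inhibition, read by sulforhodamine B assay, with a stated time of 48 h; on this read-out lower numbers stand for stronger inhibition of growth and higher numbers for weaker inhibition of growth. Compound 1, `N=C(N)c1ccc(-c2ccc(-c3cc(Cl)cc(Cl)c3)s2)s1`, gives in this assay a value of 2060 nM. Compound 2, `COc1ccc(-c2ccc(-c3ccc(C(=N)N)o3)o2)cc1`, gives in this assay a value of 860 nM. Compound 2 therefore stands at the lowest of the two numbers, and the nearest number, that of compound 1, is higher by a gap beyond the usual scatter. Within the data shown here, the two differ in several places at once, so no single-change step between them can be read from the pair.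

The next compound, compound 3, `N=C(N)c1ccc(-c2ccc(-c3ccc(Cl)cc3)o2)o1`, differs from compound 2 in one place only: chloro in place of methoxy on an aromatic carbon, with the chloro sitting on an aromatic carbon of a six-membered aromatic ring of carbon only, para to a large group. Among the measured compounds shown here, no measured pair shows this change, so the expectation rests on the shared core and on compound 2 alone.

The step from compound 2 to compound 3 is expected to be small, around a 1.2-fold higher number from compound 2 to compound 3 (0.07 log units; within the scatter), and likely within the scatter in either direction. Compound 3 is expected to give about 1000 nM in this assay, within a range of 400 nM to 2500 nM.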

Compound 3, concentration for 50% growth inhibition: 2190 nM
Compound 3: the middle estimate sits 2.2-fold (0.34 log units) below what was measured, and the stated range covers the measured number.
By their numbers in this assay, from the lowest: compound 2; then compounds 1 and 3 (each within the scatter of the next).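

In this assay, the position on the six-membered aromatic ring of carbon only, para to a large group, responds to the group it carries: chloro in place of methoxy brings a 2.5-fold higher number from compound 2 to compound 3 (0.41 log units; beyond the scatter) and so gives a modest step that lies beyond the scatter. Among these compounds, this is the first single-change step, so the methoxy of compound 2 now has a direct comparison on the shared core, and of this pair it is the methoxy compound that holds the lower number. Nothing at hand bears on why the number moves with this exchange.

A single step at a single position cannot separate what leaving methoxy contributes from what entering chloro contributes, nor can it show whether the same exchange would give a similar step on the core of compound 1. Also open, as far as these compounds go, is whether a hydroxyl, an amine, a trifluoromethyl or a longer ether such as ethoxy at this position would give a number lower than that of compound 2.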